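A Dimethylamino in Place of Methyl: What to Expect

The compounds below may be only part of what the source reports. "The series", "measured", "known", "first", "only" and "open" are said of these compounds alone.

Compound 1, `CC1=CC[C@@H]([C@@](C)(O)CCCC(C)(C)NC(=S)NN)CC1`, in a functional assay on NCI-H460 cells (Homo sapiens) for cytotoxicity, read by sulforhodamine B assay; a lower number here means a stronger inhibitor of growth, a higher number a weaker inhibitor of growth: 84000 nM.
Compound 2, `CC1=CC[C@@H]([C@@](C)(O)CCCC(C)(C)NC(=S)N/N=C\c2ccc(C)cc2)CC1`, in this assay: > 100000 nM, which is a limit of the assay and not a number.
Compound 3, `CC1=CC[C@@H]([C@@](C)(O)CCCC(C)(C)NC(=S)N/N=C\c2ccc(N(C)C)cc2)CC1`, not yet measured in this assay.

Compound 2 stands at the weak end of what has been measured: in this assay it reaches only a limit, so its true value is not known. Among the measured compounds shown here, the single measured step, an at least 1.1-fold higher number from compound 1 to compound 2 (0.07 log units; that floor lies within the scatter), rests on that limit, (the limit of > 100000 nM in this assay, at which 1 of the 2 values shown sits), and its size is therefore only a floor.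

Compound 3 differs from compound 2 in one place: dimethylamino in place of methyl on an aromatic carbon. For the measured compounds named here, no measured step touches the aromatic ring, so the data give no size for this change. The expectation is a step of no more than the scatter, with the chance that compound 3, like compound 2, again sits at the limit.

Compound 3 is estimated at 100000 nM, with a range from 30000 nM to 300000 nM. This estimate means an expected step of a number no higher from compound 2 to compound 3 (the limit leaves the size open).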

Compound 3, concentration for total growth inhibition: > 100000 nM
Compound 3: a limit, no number (the forecaster's own chance of this, stated with the estimate: 60%); the middle value sits exactly at the limit.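

Compound 3 gives > 100000 nM in this assay and this is a limit of the assay, not a number. Among the compounds shown here, compound 2 also sits at a limit, so no step between compound 2 and compound 3 can be read: the limit of > 100000 nM in this assay, at which 2 of the 3 values shown sit. The compounds shown leave open whether dimethylamino in place of methyl changes growth inhibition at all.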